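Sulfonylpiperazine series: methyl to tert-butyl on the aryl sulfonyl

The compounds below may be only part of what the source reports. "The series", "measured", "known", "first", "only" and "open" are said of these compounds alone.

Three compounds of the shared core carry different aryl groups on the sulfonyl sulfur. Compound 1 `COc1cc2nc(N3CCN(S(=O)(=O)c4cccc([N+](=O)[O-])c4)CC3)nc(N)c2cc1OC` gives 32000 nM in a functional assay on PC-3 cells (Homo sapiens) for inhibition; a lower number here means a stronger inhibitor, a higher number a weaker inhibitor. Compound 2 `COc1cc2nc(N3CCN(S(=O)(=O)c4ccc([N+](=O)[O-])cc4)CC3)nc(N)c2cc1OC` gives 36000 nM in this assay, and compound 3 `COc1cc2nc(N3CCN(S(=O)(=O)c4ccc(C)cc4)CC3)nc(N)c2cc1OC` gives 30000 nM. Compound 3 holds the lowest of the three numbers, but a 1.1-fold lower number from compound 1 to compound 3 (0.03 log units; within the scatter) and a 1.2-fold lower number from compound 2 to compound 3 (0.08 log units; within the scatter) are both within the scatter, as is a 1.1-fold higher number from compound 1 to compound 2 (0.05 log units; within the scatter), so the three compounds cannot be told apart on these numbers.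

Compound 4 `COc1cc2nc(N3CCN(S(=O)(=O)c4ccc(C(C)(C)C)cc4)CC3)nc(N)c2cc1OC` differs from compound 3 by tert-butyl in place of methyl on an aromatic carbon. Among the measured compounds shown here, no measured step changes this group in the same way. For the measured compounds named here, the only step that touches the same aromatic carbon is a 1.2-fold lower number from compound 2 to compound 3 (0.08 log units; within the scatter), a swap of a nitro for a methyl, and it left the number where it was. The other two steps move the substituent around the ring or exchange it, again without effect beyond the scatter. Every change of the aryl group recorded so far has been flat, so no step beyond the scatter is expected for no change at the digits printed from compound 3 to compound 4 (within the scatter). Compound 4 is therefore estimated at 30000 nM in this assay, with a range from 12000 nM to 80000 nM.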

Compound 4, half-maximal inhibitory concentration: 4100 nM
For compound 4 the middle estimate is 7.3-fold (0.86 log units) above the measured one; measured number outside the range, below it.
By their numbers in this assay, from the lowest: compound 4; then compounds 3, 1 and 2 (each within the scatter of the next).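

In this assay the aryl group on the sulfonyl sulfur turns out not to be a silent position: with tert-butyl in place of methyl on the same aromatic carbon, the series shows a 7.3-fold lower number from compound 3 to compound 4 (0.86 log units; beyond the scatter), its first change beyond the scatter. The result holds whichever earlier compound serves as the reference, with an 8.8-fold lower number from compound 2 to compound 4 (0.94 log units; beyond the scatter) where tert-butyl replaces nitro and a 7.8-fold lower number from compound 1 to compound 4 (0.89 log units; beyond the scatter) where 4-(tert-butyl)phenyl replaces 3-nitrophenyl, all of them beyond the scatter. Methyl and nitro, with nitro in either ring placement, remain within the scatter of each other, so among the groups shown only the 4-(tert-butyl)phenyl group separates from the rest. Nothing available here bears on why this one group moves the number.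

On these data alone, it remains open whether the number follows the size of the alkyl group, which ethyl, isopropyl or a longer chain on the same aromatic carbon would address. As far as these compounds go, it is equally open whether the tert-butyl result is specific to carbon-only substituents, which an amine or a carboxylic acid at that carbon would test.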